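A few compounds are considered here, and "the series" means these few. Any claim that something is new, unique, unknown or untested is made for them only; others in the source may bear on it.

Measured in a functional assay on MCF7 cells (Homo sapiens) for antiproliferative activity, read by MTT assay, with a stated time of 48 h; a higher number here means a weaker inhibitor, a lower number a stronger inhibitor:
- Compound 1 `C=C(c1ccc(OC)cc1NC(=O)CN)c1ccc(OC)c2c1C=CC(C)(C)O2`: 780 nM
- Compound 2 `C=C(c1ccc(OC)cc1NC(=O)CNC)c1ccc(OC)c2c1C=CC(C)(C)O2`: 1010 nM
- Compound 3 `C=C(c1ccc(OC)cc1NC(=O)CNCC)c1ccc(OC)c2c1C=CC(C)(C)O2`: 2920 nM

Compound 3 has the highest number of the three, and its steps to both others lie beyond the scatter. Compound 4 `C=C(c1ccc(OC)cc1NC(=O)CN(C)C)c1ccc(OC)c2c1C=CC(C)(C)O2` has the same atoms as compound 3, joined differently: dimethylamino in place of ethylamino on a saturated chain carbon bound to a carbonyl carbon. Among the compounds with values here, three measured steps bear on this change: a 1.3-fold higher number from compound 1 to compound 2 (0.11 log units; within the scatter), a 2.9-fold higher number from compound 2 to compound 3 (0.46 log units; beyond the scatter) and a 3.7-fold higher number from compound 1 to compound 3 (0.57 log units; beyond the scatter). Within the data shown here, the first is within the scatter and the other two are modest, but no measured compound carries dimethylamino. A small step toward a lower number is therefore expected: a 1.9-fold lower number from compound 3 to compound 4 (0.29 log units; within the scatter). For compound 4 the estimated value is 1500 nM, with an expected range of 700 nM to 3300 nM.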

Compound 4, half-maximal inhibitory concentration: 2580 nM
Compound 4: middle estimate off by 1.7-fold (0.24 log units), on the low side, and the stated range covers the measured number.
By their numbers in this assay, from the lowest: compounds 1 and 2 (each within the scatter of the next); then compounds 4 and 3 (each within the scatter of the next).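

In this assay, joining the same atoms as dimethylamino rather than ethylamino on this saturated chain carbon makes no readable difference (a 1.1-fold lower number from compound 3 to compound 4 (0.05 log units; within the scatter)), although the hydrogen-bond donor is lost. A second methyl on the amine nitrogen does move the number modestly (a 2.6-fold higher number from compound 2 to compound 4 (0.41 log units; beyond the scatter)), and dimethylamino in place of amino gives a similar modest step (a 3.3-fold higher number from compound 1 to compound 4 (0.52 log units; beyond the scatter)), so among these compounds the size of the step follows the two added carbons, however they are joined, and no evidence is available to explain this. From the compounds shown here alone, whether a propylamino chain, or a ring amine such as pyrrolidine or morpholine, would continue this trend remains open.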